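Chloro to bromo swap carried from one core to another

The source may report more compounds than this note shows. Statements on the series, on what has been measured and on what is new or still open speak of the compounds shown alone.

Compound 1 `Cc1cc(C)cc(Cn2c(SCC(=O)Nc3ccccc3Cl)nc3ccc(Cl)cc32)c1` and compound 3 `Cc1cc(C)cc(Cn2c(SCC(=O)Nc3ccccc3Br)nc3ccc(Cl)cc32)c1` share one core; compound 2 `Cc1cc(C)cc(S(=O)(=O)n2c(SCC(=O)Nc3ccccc3Cl)nc3ccccc32)c1` and compound 4 `Cc1cc(C)cc(S(=O)(=O)n2c(SCC(=O)Nc3ccccc3Br)nc3ccccc32)c1` share another. The difference between the two cores is not broken down here. In an ADME assay on MT4 cells (Homo sapiens) for cytotoxicity (on this read-out higher numbers stand for lower toxicity in this test and lower numbers for higher toxicity in this test), compound 1 gives 141000 nM, compound 3 gives 174000 nM and compound 2 gives 107000 nM; the three numbers lie within the scatter of one another, so no order among them is read.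

The change from compound 1 to compound 3 is bromo in place of chloro on an aromatic carbon. Its step in this assay is a 1.2-fold higher number from compound 1 to compound 3 (0.09 log units; within the scatter). The change from compound 2 to compound 4 is bromo in place of chloro on an aromatic carbon; the place reads the same in both cases, so this is the same change made on the second core. Compound 4 has not yet been measured in this assay.

The expectation rests on the measured pair alone: because the first core gave a 1.2-fold higher number from compound 1 to compound 3 (0.09 log units; within the scatter), the step expected here is a 1.2-fold higher number from compound 2 to compound 4 (0.07 log units; within the scatter), a change that would stay within the scatter. For compound 4 the estimate in this assay is 125000 nM, with a range from 70000 nM to 220000 nM.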

Compound 4, half-maximal cytotoxic concentration: >= 235000 nM
Compound 4 ended at the assay's limit; the forecaster's own chance of this, stated with the estimate: 10%; at least 1.8-fold (0.27 log units) between middle value and limit.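

Compound 4 stands at >= 235000 nM, which is a limit of this assay and not a number. Carried to the core of compound 2, bromo in place of chloro gives an at least 2.1-fold higher number from compound 2 to compound 4 (0.34 log units; beyond the scatter), so on this core the step lies beyond the scatter, whereas on the core of compound 1 it stayed within it. This does not show that the change behaves differently on the two cores, and the comparison stays unsettled: the same change on two cores in this assay, a 1.2-fold higher number (0.09 log units; within the scatter) from compound 1 to compound 3 and an at least 2.1-fold higher number (0.34 log units; beyond the scatter) from compound 2 to compound 4; the limit leaves it open whether they differ

The compounds shown carry only chloro and bromo at this place on the aromatic ring, so a fluoro, a methoxy or a nitrile there remains open. Also open, from the compounds shown here alone, are the size of the step on the second core, which has only a lower bound, and which part of the difference between the two cores goes with the larger step.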